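The compounds below may be only part of what the source reports. "The series", "measured", "known", "first", "only" and "open" are said of these compounds alone.

Working notes on the series. In a functional assay on MIA PaCa-2 cells (Homo sapiens) for inhibition, read by MTT assay, with a stated time of 48 h, tested at 10 uM (a higher number here means more inhibition of growth at the concentration tested, a lower number less inhibition of growth), compound 1 `Cc1cc(=O)c2c(O)cc(OCc3ccc([N+](=O)[O-])cc3)c([C@H]3CCN(C)C[C@H]3O)c2o1` gives 12% and compound 2 `CCN(CC)Cc1c(O)c([C@H]2CCN(C)C[C@H]2O)c2oc(C)cc(=O)c2c1O` gives 27%, while compound 3 `CN1CC[C@H](c2c(O)cc(O)c3c(=O)cc(/C=C/c4ccccc4)oc23)[C@H](O)C1` reaches 87% and stands highest of the three, beyond the scatter from both others. Within the data shown here, compound 1 and compound 2 each differ from compound 3 in more than one place, so the three offer no single-change step, and the gap cannot be assigned to any one group.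

Compound 4 `CN1CC[C@H](c2c(O)cc(O)c3c(=O)cc(/C=C/c4cccc(F)c4)oc23)[C@H](O)C1` matches compound 3 except for one change, which turns 2-phenylethenyl into 2-(3-fluorophenyl)ethenyl: fluoro in place of hydrogen on an aromatic carbon. This is fluoro in place of hydrogen on an aromatic carbon, meta to a large group.

Among the measured compounds shown here, no measured pair shows what such a change does, so the expectation rests only on compound 3 at 87% and on the small size of the change. The expected size in this assay is none beyond the scatter, with at most a slight fall. The estimated step of a number 5 percentage points lower from compound 3 to compound 4 (within the scatter) is therefore expected to stay within the scatter. In this assay the estimate for compound 4 is 82%, with an expected range of 62% to 97%.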

Compound 4, percent growth inhibition at one concentration: 67%
Estimate against measurement, compound 4: 15 percentage points above; measured number inside the range.
By their numbers in this assay, from the lowest: compound 1; then compound 2; then compound 4; then compound 3.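

Among these compounds, the first single-change step lies on the phenyl of the 2-phenylethenyl group: in this assay, fluoro in place of hydrogen on an aromatic carbon, meta to a large group, gives a number 20 percentage points lower from compound 3 to compound 4 (beyond the scatter). This position therefore responds to a change of 1 heavy atom beyond the scatter, although the step is modest and compound 4 still gives 67%. Nothing measured here speaks to the cause of this step.

On these data alone, it remains open whether the fall is specific to fluoro or follows any replacement of hydrogen on this carbon; a single substituent at a single place defines no trend, and chloro, methoxy or an amine on the same carbon would separate these readings. As far as these compounds go, it is also open whether fluoro on another carbon of the same six-membered aromatic ring gives a step of similar size, or whether the response depends on this particular place.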